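Isobutyl for Ethyl on the Amino Nitrogen of a CRF1 Ligand

The compounds below may be only part of what the source reports. "The series", "measured", "known", "first", "only" and "open" are said of these compounds alone.

Compound 1 `COCc1cc(OC)c(-c2csc3c(N(CC4CCOCC4)CC4CC4)c(C)nn23)c(OC)c1` gives 46 nM
Compound 2 `COCc1cc(OC)c(-c2csc3c(N(CC4CC4)CC4CCCCO4)c(OC)nn23)c(OC)c1` gives 75 nM
Compound 3 `CCN(c1c(OC)nn2c(-c3c(OC)cc(COC)cc3OC)csc12)C1CCOCC1` gives 147 nM

Of the compounds shown here, three sharing one core have been measured in an assay on HEK293 cells for displacement of a labelled ligand from corticotropin-releasing factor receptor 1 (Homo sapiens), read by scintillation proximity assay, with a stated time of 2 h; a higher number here means a weaker inhibitor, a lower number a stronger inhibitor. Compound 3 stands at the highest of the three numbers. Its nearest neighbour is compound 2, whose value of 75 nM lies within the usual scatter of that of compound 3, so no order between these two can be claimed. Compound 1, with 46 nM, is further away, and that gap lies beyond the scatter.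

Compound 4 `COCc1cc(OC)c(-c2csc3c(N(CC(C)C)C4CCOCC4)c(OC)nn23)c(OC)c1` has not yet been measured in this assay. It differs from compound 3 in one place: isopropyl in place of methyl on a saturated chain carbon bound to a nitrogen on an aromatic ring. Read one bond further out, the ethyl on the amino nitrogen becomes an isobutyl, so that the ethyl(oxan-4-yl)amino group of compound 3 becomes an isobutyl(oxan-4-yl)amino group.

For the measured compounds named here, no pair of measured compounds differs in exactly this way, so the size of this step can only be guessed from the spread of the three values. The account expects a small step from compound 3 to compound 4 toward a lower number, a 1.7-fold lower number from compound 3 to compound 4 (0.24 log units; within the scatter), most likely within the scatter. Compound 4 is thus estimated at 85 nM, with a range from 30 nM to 250 nM.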

Compound 4, half-maximal inhibitory concentration: 91 nM
The estimate for compound 4 lay 1.1-fold (0.03 log units) below the measured number, within the range that was stated.
By their numbers in this assay, from the lowest: compounds 1, 2, 4 and 3 (each within the scatter of the next, the first and the last beyond it).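

In this assay the shared core now has its first pair of compounds that differ in one place, and it gives a 1.6-fold lower number from compound 3 to compound 4 (0.21 log units; within the scatter) for the exchange of ethyl for isobutyl on the amino nitrogen. The earlier compounds shown here each differed in more than one place and so could say nothing about this position alone; this pair shows that, with the oxan-4-yl group and the methoxy group of compound 3 held constant, isobutyl is accepted here with no change that can be told from the scatter of the assay. A single pair cannot explain why the step is this small, and no independent measurement bearing on this result is at hand.

The compounds shown leave open whether anything placed on this nitrogen can move the number beyond the scatter, for instance a benzyl group, a longer chain such as hexyl, or a chain ending in an amine or a carboxylic acid. They also leave open whether ethyl and isobutyl would remain as close together with a different second group on that nitrogen, such as the cyclopropylmethyl found in compound 1.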